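The source may hold more compounds than are shown below. What is called first, only, known or untested is meant among the compounds shown, and "the series" means these compounds.

Among the compounds with values here, compound 2 `CC(C)(C)C(=O)NC[C@@H]1CCCc2cc(S(=O)(=O)c3cccc(F)c3)ccc21` stands at the higher end of the two numbers measured so far in an assay on isolated protein for displacement of a labelled ligand from 5-hydroxytryptamine receptor 6 (Homo sapiens) (a higher number here means a weaker inhibitor, a lower number a stronger inhibitor), where compound 2 gives 3.98 nM. Within the data shown here, its only neighbour, compound 1 `NC(=O)NC[C@@H]1CCCc2cc(S(=O)(=O)c3cccc(F)c3)ccc21`, gives 0.2 nM in this assay. Among the measured compounds shown here, the one measured step, a 20-fold higher number from compound 1 to compound 2 (1.30 log units; beyond the scatter), arose from tert-butyl in place of amino on a carbonyl carbon, so the group attached to the saturated chain carbon is already known to matter greatly. Compound 3 `CN(C[C@@H]1CCCc2cc(S(=O)(=O)c3cccc(F)c3)ccc21)S(C)(=O)=O` differs from compound 2 by methyl(methylsulfonyl)amino in place of ((tert-butyl)carbonyl)amino on a saturated chain carbon bound to a saturated ring carbon. For the measured compounds named here, no measured step covers this exact change; the earlier step touches the same region but alters a different part of it, and it is the only available guide. Compound 3 is expected to give a somewhat higher number than compound 2, a step of a 2.5-fold higher number from compound 2 to compound 3 (0.40 log units; beyond the scatter), though a result within the scatter cannot be excluded. Compound 3 is therefore estimated at 10 nM in this assay, within the range 2 nM to 60 nM.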

Compound 3, inhibition constant: 0.398 nM
For compound 3 the middle estimate is 25-fold (1.40 log units) above the measured one; the whole stated range lies above it.
By their numbers in this assay, from the lowest: compounds 1 and 3 (each within the scatter of the next); then compound 2.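

In this assay, methyl(methylsulfonyl)amino in place of ((tert-butyl)carbonyl)amino on a saturated chain carbon bound to a saturated ring carbon brings a 10-fold lower number from compound 2 to compound 3 (1.00 log units; beyond the scatter) and so recovers most of what the tert-butyl amide had lost. The other new step, a 2.0-fold higher number from compound 1 to compound 3 (0.30 log units; within the scatter), leaves methyl(methylsulfonyl)amino and ureido indistinguishable here, which shows that a low number at this place does not require a carbonyl group or a hydrogen-bond donor in the group, since the entering group has neither. No measurement is available to explain why these groups differ as they do. The compounds shown change the methyl on nitrogen and the methylsulfonyl together, so their separate contributions stay unresolved. An unmethylated methylsulfonylamino group, a longer chain on the sulfonyl or a simple amine at this place would address that.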